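Thiophene for chlorophenyl at the aryl position: expected cytotoxicity

The compounds below may be only part of what the source reports. "The series", "measured", "known", "first", "only" and "open" are said of these compounds alone.

Measured compounds:
Compound 1, `Cc1cc(C#N)cc(C)c1Oc1nc(Nc2ccc(C#N)cc2)ncc1-c1ccncc1`, gives 28000 nM in an ADME assay on MT4 cells (Homo sapiens) for cytotoxicity, read by MTT assay, with a stated time of 5 days; on this read-out higher numbers stand for lower toxicity in this test and lower numbers for higher toxicity in this test.
Compound 2, `Cc1cc(C#N)cc(C)c1Oc1nc(Nc2ccc(C#N)cc2)ncc1-c1ccc(-c2ccccc2)cc1`, sits at a limit of this assay rather than a number, > 253000 nM.
Compound 3, `Cc1cc(C#N)cc(C)c1Oc1nc(Nc2ccc(C#N)cc2)ncc1-c1ccc(Cl)cc1`, gives 72600 nM in this assay.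

Among the two numbers reported, compound 3 holds the higher one, with compound 1 as its nearest neighbour through the step of a 2.6-fold higher number from compound 1 to compound 3 (0.41 log units; beyond the scatter). The third value, that of compound 2, is only a limit (the limit of > 253000 nM in this assay, at which 1 of the 3 values shown sits).

Compound 4, `Cc1cc(C#N)cc(C)c1Oc1nc(Nc2ccc(C#N)cc2)ncc1-c1ccsc1`, has not yet been measured. It differs from compound 3 in one place: thiophen-3-yl in place of 4-chlorophenyl on an aromatic carbon.

For the measured compounds named here, two measured steps bear on this change. The step of a 2.6-fold higher number from compound 1 to compound 3 (0.41 log units; beyond the scatter) shows that exchanging pyridin-4-yl for 4-chlorophenyl raised the number by a modest amount, while the step of an at least 3.4-fold lower number from compound 2 to compound 3 (0.54 log units; beyond the scatter) shows that chloro in place of phenyl lowered it. Thiophen-3-yl is a smaller heteroaromatic group than 4-chlorophenyl, and its single hydrogen-bond acceptor brings it closer to pyridin-4-yl than to 4-phenylphenyl. Compound 4 is therefore expected to move toward compound 1, with a modest lower step a 1.7-fold lower number from compound 3 to compound 4 (0.24 log units; within the scatter). The estimate for compound 4 in this assay is 42000 nM, within a range from 17000 nM to 105000 nM.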

Compound 4, half-maximal cytotoxic concentration: 3920 nM
Estimate against measurement, compound 4: 11-fold (1.03 log units) above, and the stated range ends above it.
By their numbers in this assay, from the lowest: compound 4; then compound 1; then compound 3. At a limit, above all of these: compound 2.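

The result shows that this position, ortho to a 4-cyano-2,6-dimethylphenoxy group, does not only raise the number in this assay when pyridin-4-yl is replaced: thiophen-3-yl is the first replacement shown that lowers it (a 7.1-fold lower number from compound 1 to compound 4 (0.85 log units; beyond the scatter)). The change from 4-chlorophenyl is larger still (a 19-fold lower number from compound 3 to compound 4 (1.27 log units; beyond the scatter)), so a five-membered aromatic ring with 1 hetero atom gives the lowest number of the series, and the gain seen with 4-chlorophenyl does not carry over to every aryl group at this position. Compound 2 is read only through its limit, which makes its step to the thiophene a minimum (an at least 64-fold lower number from compound 2 to compound 4 (1.80 log units; beyond the scatter)) and leaves the full span of the position unknown: (the limit of > 253000 nM in this assay, at which 1 of the 4 values shown sits).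

The compounds shown leave open whether the low number belongs to thiophen-3-yl alone or extends to thiophen-2-yl, furan-3-yl or another five-membered ring such as pyrazole. They also say nothing about how this position responds to a non-aromatic group such as morpholine or an amine, and they give no reason for the drop.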